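The compounds below may be only part of what the source reports. "The series", "measured", "known", "first", "only" and "open" are said of these compounds alone.

Compound 2 `CCC(=O)N1CCC(NC(=O)Nc2ccc(OC(F)(F)F)c(F)c2)CC1` and compound 1 `O=C(Nc1ccc(OC(F)(F)F)cc1)NC1CCN(C(=O)C2CCCOC2)CC1` were both tested in a physicochemical assay for solubility, read by mass spectrometry, in phosphate buffer, with a stated time of 24 h, at pH 7.4; on this read-out higher numbers stand for higher solubility and lower numbers for lower solubility. Compound 1 gives 94 ug/mL. Compound 2 gives 11 ug/mL, the lower of the two numbers, with compound 1 standing above it by a gap beyond the usual scatter. The two compounds differ in more than one place, so no single change can be tied to that gap. Compound 3 `O=C(Nc1ccc(OC(F)(F)F)c(F)c1)NC1CCN(C(=O)C2CCCOC2)CC1` has not been measured in this assay. It differs from compound 2 in one place: oxan-3-yl in place of ethyl on a carbonyl carbon. Compound 3 thus carries the same (oxan-3-yl)carbonyl group as compound 1, while keeping the fluorine of compound 2. Because compound 1 gives 94 ug/mL with that same group, a rise is expected. The step of a 4.1-fold higher number from compound 2 to compound 3 (0.61 log units; beyond the scatter) is estimated to be upward and well beyond the scatter. Compound 3 is therefore expected to reach about 45 ug/mL, within a range from 14 ug/mL to 130 ug/mL.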

Compound 3, solubility: 174 ug/mL
Beside the measured number, compound 3's estimate is 3.9-fold (0.59 log units) below it; measured number above the stated range.
By their numbers in this assay, from the lowest: compound 2; then compounds 1 and 3 (each within the scatter of the next).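

In this assay, oxan-3-yl in place of ethyl on a carbonyl carbon, with the rest of the molecule unchanged, gives a 16-fold higher number from compound 2 to compound 3 (1.20 log units; beyond the scatter), so the group at this position has a large bearing on the number. Fluoro in place of hydrogen on an aromatic carbon gives a 1.9-fold higher number from compound 1 to compound 3 (0.27 log units; within the scatter), so with the (oxan-3-yl)carbonyl group in place, this read-out does not separate the two compounds. Nothing at hand gives a cause for either step.

The compounds shown leave open whether the large step goes with the ring of oxan-3-yl or with its oxygen; a cyclohexyl group, which has a ring without oxygen, or a methoxyethyl chain, which has oxygen without a ring, would help separate the two. As far as these compounds go, whether the fluoro change would also stay within the scatter alongside ethyl remains open too.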